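This account rests on a few compounds, and the source may have more. Where it says the series, first, only, none or still open, it means among the compounds named here.

Measured so far:
- compound 1, `COc1cc(C(=O)NS(=O)(=O)c2ccccc2OC)ccc1Cn1ccc2ccc(NC(=O)CC3CCCC3)cc21`: 9.7
- compound 2, `COc1cc(C(=O)NS(=O)(=O)c2cc(C)ccc2C)ccc1Cn1ccc2ccc(NC(=O)CC3CCCC3)cc21`: 8.4

Both numbers come from a functional assay (trachea) for antagonist activity, with Cavia porcellus as the target; a higher number here means a more potent compound, by a factor of ten per unit of this negative logarithm, a lower number a less potent compound. Among the measured compounds shown here, compound 2 stands at the lower of the two values, and the only measured step, a number 1.30 log units lower from compound 1 to compound 2 (beyond the scatter), is a large loss that comes from swapping the 2-methoxyphenyl of compound 1 for a 2,5-dimethylphenyl on the sulfonyl sulfur.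

Compound 3, `COc1cc(C(=O)NS(=O)(=O)c2ccccn2)ccc1Cn1ccc2ccc(NC(=O)CC3CCCC3)cc21`, changes that same place once more: pyridin-2-yl in place of 2,5-dimethylphenyl on a sulfonyl sulfur. For the measured compounds named here, no measured step covers a pyridin-2-yl here, so the expectation leans on one observation only: the group on the sulfonyl sulfur matters strongly, as a number 1.30 log units lower from compound 1 to compound 2 (beyond the scatter) shows, and the group entering in compound 3 is, like the 2-methoxyphenyl of compound 1, a six-membered ring carrying one hydrogen-bond acceptor rather than two methyls. A recovery toward compound 1 is therefore expected, though with wide uncertainty. Compound 3 is estimated at 9, in a range of 8 to 10. The expected step is a number 0.60 log units higher from compound 2 to compound 3 (beyond the scatter).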

Compound 3, negative logarithm of the antagonist equilibrium constant: 8.9
Beside the measured number, compound 3's estimate is 0.10 log units above it; measured number inside the range.
By their numbers in this assay, from the lowest: compound 2; then compound 3; then compound 1.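

In this assay, pyridin-2-yl on the sulfonyl sulfur wins back part of what the 2,5-dimethylphenyl gave up, with a number 0.50 log units higher from compound 2 to compound 3 (beyond the scatter), but it does not reach the 2-methoxyphenyl, with a number 0.80 log units lower from compound 1 to compound 3 (beyond the scatter). The position therefore separates three groups rather than two, and since the 2-methoxyphenyl and pyridin-2-yl groups both hold a hydrogen-bond acceptor yet still differ beyond the scatter, having an acceptor in this group does not alone set the potency. No measurement shown here accounts for these differences.

The compounds shown do not separate the ring nitrogen from the loss of the two methyls, which a plain phenyl or a pyridin-3-yl at this place could address. On these data alone, how a 2-methylphenyl or a 2-ethoxyphenyl would compare also remains open.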